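Bromo on the thiourea phenyl: expected cytotoxicity

The compounds below may be only part of what the source reports. "The series", "measured", "known", "first", "only" and "open" are said of these compounds alone.

For the measured compounds named here, compound 2 `N#CC1=C(NC(=S)Nc2ccccc2)N(c2ccc(S(N)(=O)=O)cc2)C2=C(C(=O)CCC2)C1c1ccc(Cl)cc1Cl` gives 55% in a functional assay on Ehrlich cells (Mus musculus) for cytotoxicity, read by trypan blue exclusion, with a stated time of 2 h, tested at 50 ug/mL (on this read-out lower numbers stand for a weaker effect and higher numbers for a stronger effect at the one concentration tested), the lower of the two numbers at hand, though within scatter of its only neighbour. Compound 1 `N#CC1=C(N)N(c2ccc(S(N)(=O)=O)cc2)C2=C(C(=O)CCC2)C1c1ccc(Cl)cc1Cl` gives 65% in this assay, and the step of a number 10 percentage points lower from compound 1 to compound 2 (within the scatter) lies within the scatter. Compound 3 `N#CC1=C(NC(=S)Nc2ccc(Br)cc2)N(c2ccc(S(N)(=O)=O)cc2)C2=C(C(=O)CCC2)C1c1ccc(Cl)cc1Cl` carries the change (bromo in place of hydrogen on an aromatic carbon). Going by the values given here, no measured step exchanges hydrogen for bromo on that ring; the single measured step, the large addition from compound 1 to compound 2, stayed within scatter. The expected step is therefore no change at the digits printed from compound 2 to compound 3 (within the scatter), none beyond the scatter. Compound 3 is estimated at 55%, within 40% to 70%.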

Compound 3, a percentage reported as activity, at one concentration (the size of the read-out at that concentration, not a potency): 90%
Compound 3: the middle estimate sits 35 percentage points below what was measured, outside the stated range (above it).
By their numbers in this assay, from the lowest: compounds 2 and 1 (each within the scatter of the next); then compound 3.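

In this assay the change from phenyl to 4-bromophenyl gives a number 35 percentage points higher from compound 2 to compound 3 (beyond the scatter) and shows that this aromatic carbon matters, although the whole thiourea addition had stayed within the scatter. With the bromo in place, the addition on the amine nitrogen gives a number 25 percentage points higher from compound 1 to compound 3 (beyond the scatter) and so reads beyond the scatter, which the same addition without bromo did not. No data at hand bear on the reason for this step.

As far as these compounds go, whether chloro, methoxy or an amine at this carbon gives a similar number remains open. So does the effect of bromo elsewhere on this ring.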